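A few compounds are considered here, and "the series" means these few. Any claim that something is new, unique, unknown or untested is made for them only; others in the source may bear on it.

Compound 1 `CC1=CC[C@H](C(C)(C)NC(=S)N/N=C/c2ccccc2)CC1` and compound 2 `CC1=CC[C@H](C(C)(C)NC(=S)N/N=C/c2ccc(Cl)cc2)CC1` are the two measured compounds. In a functional assay on NCI-H460 cells (Homo sapiens) for inhibition, read by sulforhodamine B assay, with a stated time of 48 h (a higher number here means a weaker inhibitor of growth, a lower number a stronger inhibitor of growth), compound 1 gives 53900 nM and compound 2 gives 21100 nM.

For the measured compounds named here, compound 2 therefore holds the lowest of the two numbers in this assay; the only measured step, a 2.6-fold lower number from compound 1 to compound 2 (0.41 log units; beyond the scatter), separates it from compound 1. Compound 3 `CC1=CC[C@H](C(C)(C)NC(=S)N/N=C/c2ccco2)CC1` is not yet measured. Going by the values given here, it differs from compound 2 by furan-2-yl in place of 4-chlorophenyl on a carbon with a double bond to nitrogen, so the chloro whose introduction made up the step of a 2.6-fold lower number from compound 1 to compound 2 (0.41 log units; beyond the scatter) is lost along with the whole benzene ring, and no measured step covers the aromatic ring itself. The expectation rests only on that chloro step: because a 2.6-fold lower number from compound 1 to compound 2 (0.41 log units; beyond the scatter) was gained by the chloro, its removal is expected to return the number toward that of compound 1, so a 1.9-fold higher number from compound 2 to compound 3 (0.28 log units; within the scatter) is expected. For compound 3 the estimate in this assay is 40000 nM, with a range from 15000 nM to 110000 nM.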

Compound 3, concentration for total growth inhibition: 10800 nM
Estimate against measurement, compound 3: 3.7-fold (0.57 log units) above; measured number below the stated range.
By their numbers in this assay, from the lowest: compounds 3 and 2 (each within the scatter of the next); then compound 1.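

At this position, on a carbon with a double bond to nitrogen, the aromatic ring itself can be exchanged, not only substituted: in this assay, furan-2-yl in place of phenyl gives a 5.0-fold lower number from compound 1 to compound 3 (0.70 log units; beyond the scatter), the largest step among these compounds. Furan-2-yl in place of 4-chlorophenyl gives a 2.0-fold lower number from compound 2 to compound 3 (0.29 log units; within the scatter), so the unsubstituted five-membered ring stands level with the chlorinated benzene ring, and a chloro is not required to reach this range. Nothing at hand accounts for these steps.

As far as these compounds go, whether a chloro on the furan ring would lower the number, as it did on the benzene ring, remains open. So does whether a thiophene or pyridine ring, or a furan ring joined through its 3-position, would match furan-2-yl on this core.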